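Methoxy in Place of Trifluoromethyl at a Second Ring Position

A few compounds are considered here, and "the series" means these few. Any claim that something is new, unique, unknown or untested is made for them only; others in the source may bear on it.

Compound 1 `C#CCNC1CCc2c(SCc3ccc(C(F)(F)F)cc3)cccc21` gives 930 nM in an ADME assay on isolated protein for inhibition of Amine oxidase [flavin-containing] B (Homo sapiens); a lower number here means a stronger inhibitor, a higher number a weaker inhibitor.
Compound 2 `C#CCNC1CCc2c(SCc3ccc(OC)cc3)cccc21` gives 3960 nM.
Compound 3 `C#CCNC1CCc2c(SCc3cccc(C(F)(F)F)c3)cccc21` gives 7710 nM.

Compound 2 differs from compound 1 by methoxy in place of trifluoromethyl on an aromatic carbon, and that gave a 4.3-fold higher number from compound 1 to compound 2 (0.63 log units; beyond the scatter). Compound 3 and compound 1 share their atoms joined differently; the difference between the two cores is not broken down here. Compound 3 has the highest number of the three, beyond the scatter against compound 1 but within it against compound 2. Compound 4 `C#CCNC1CCc2c(SCc3cccc(OC)c3)cccc21` is not yet measured; it differs from compound 3 by methoxy in place of trifluoromethyl on an aromatic carbon, the same kind of change, though here the group sits meta to a large group rather than para to a large group. Resting on a 4.3-fold higher number from compound 1 to compound 2 (0.63 log units; beyond the scatter), the step is expected to be a 2.9-fold higher number from compound 3 to compound 4 (0.46 log units; beyond the scatter) in this assay. Compound 4 is estimated at 22000 nM, likely between 6000 nM and 70000 nM.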

Compound 4, half-maximal inhibitory concentration: 1520 nM
For compound 4 the middle estimate is 14-fold (1.16 log units) above the measured one, outside the stated range (below it).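

In this assay putting methoxy in place of trifluoromethyl gave a 5.1-fold lower number from compound 3 to compound 4 (0.71 log units; beyond the scatter) and so improved inhibition, while the same change on the core of compound 1 weakened it. The two steps differ in direction and in more than the scatter allows: the same change on two cores in this assay, a 4.3-fold higher number (0.63 log units; beyond the scatter) from compound 1 to compound 2 and a 5.1-fold lower number (0.71 log units; beyond the scatter) from compound 3 to compound 4, 22-fold (1.33 log units) apart, beyond the scatter of two such steps. This shows that the effect of this change did not carry from one core to the other here, but two pairs cannot show why, or predict what it would do on a further core.

The compounds shown leave open how a nitrile or a chlorine atom would compare in place of these two groups. They also leave open how a plain hydrogen there would compare, which would give both pairs a common reference.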